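The compounds below may be only part of what the source reports. "The series", "measured", "known", "first", "only" and "open" are said of these compounds alone.

In a functional assay on HeLa cells (Homo sapiens) for antiproliferative activity, read by MTT assay, with a stated time of 72 h (a lower number here means a stronger inhibitor, a higher number a weaker inhibitor), compound 3 `COc1cc(-c2nccn2CC(C)C)cc(OC)c1OC` shows > 100000 nM as a limit and not a number. Compound 1 `CCn1ccnc1-c1cc(OC)c(OC)c(OC)c1` shows > 100000 nM as a limit too. Compound 2 `COc1cc(-c2nccn2C(C)C)cc(OC)c1OC` shows > 100000 nM as a limit too. Among the compounds with values here, the series thus stands at the limit of > 100000 nM in this assay, at which 3 of the 3 values shown sit, and no compound has a number yet. Compound 4 `CCCCCn1ccnc1-c1cc(OC)c(OC)c(OC)c1` differs from compound 3 by butyl in place of isopropyl on a saturated chain carbon bound to an aromatic nitrogen and in words this is butyl in place of isopropyl on a saturated chain carbon bound to an aromatic nitrogen. The measured steps bearing on it are a step that the two limits leave unreadable from compound 1 to compound 3 and a step that the two limits leave unreadable from compound 2 to compound 3 and a step that the two limits leave unreadable from compound 1 to compound 2 and none of them has a size to carry over. In this assay the expected change is a number no higher from compound 3 to compound 4 (the limit leaves the size open) and no step beyond the scatter is expected in either direction. Compound 4 is expected at 100000 nM within an estimated range from 30000 nM to 200000 nM and the assay may well report only a limit again.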

Compound 4, half-maximal inhibitory concentration: > 100000 nM
Compound 4: no number, only a limit (the forecaster's own chance of this, stated with the estimate: 85%); the middle value sits exactly at the limit.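

Compound 4 gives only a limit in this assay, like compound 1, compound 2 and compound 3, and no step among these four can be read. The compounds shown leave open whether any chain on this aromatic nitrogen gives a true number: the limit of > 100000 nM in this assay, at which 4 of the 4 values shown sit.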